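The source may report more compounds than this note shows. Statements on the series, on what has been measured and on what is new or still open speak of the compounds shown alone.

Measured compounds:
compound 1, `CC1=CC(=O)c2c(O)cc(CCc3ccccc3O)cc2OC1`: > 40000 nM
compound 2, `CC1=CCc2c(O)cc(CCc3ccccc3)cc2OC1`: > 40000 nM

In a functional assay on SMMC-7721 cells (Homo sapiens) for cytotoxicity, read by MTT assay, with a stated time of 48 h (a lower number here means a stronger inhibitor, a higher number a weaker inhibitor), compound 1 gives > 40000 nM, which is a limit of the assay rather than a number. Compound 2, `CC1=CCc2c(O)cc(CCc3ccccc3)cc2OC1`, likewise gives > 40000 nM in this assay, again a limit and not a number. Both measured values therefore sit at the limit of > 40000 nM in this assay, at which 2 of the 2 values shown sit, so compound 2 stands at that limit together with compound 1, and no ordering between the two can be read from the numbers shown.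

Compound 3, `CC1=CCc2c(O)cc(CCc3ccccc3O)cc2OC1`, has not yet been measured in this assay. It differs from compound 2 in one place: hydroxy in place of hydrogen on an aromatic carbon. Compound 1 already carries the 2-hydroxyphenyl group and reaches only the limit, so no movement beyond the scatter is expected from this change. For compound 3 the expected step is a number no higher from compound 2 to compound 3 (the limit leaves the size open). Compound 3 is thus estimated at 40000 nM, within 20000 nM to 80000 nM, most likely reported again as a limit.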

Compound 3, half-maximal inhibitory concentration: 40000 nM
Beside the measured number, compound 3's estimate shows no gap at the digits printed, within the range that was stated.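

In this assay compound 3 gives 40000 nM, a measured number. The earlier compounds shown here gave only limits. The change from phenyl to 2-hydroxyphenyl, on an aromatic carbon ortho to a large group, thus gives a number no higher from compound 2 to compound 3 (the limit leaves the size open), so hydroxy at this place is compatible with a readable value, though not with a value that marks the compound as a strong inhibitor. The size of the step stays unreadable, and the series remains at the weak end of this assay: the limit of > 40000 nM in this assay, at which 2 of the 3 values shown sit.

From the compounds shown here alone, whether any group at this place can bring the value clearly lower remains open. A methoxy group, an amine or a carboxylic acid in place of the hydroxy could answer that, but none of them is among the compounds shown.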